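Chloro for Trifluoromethyl on the Methoxy Urea Analogue

This account rests on a few compounds, and the source may have more. Where it says the series, first, only, none or still open, it means among the compounds named here.

Measured compounds:
compound 1, `O=C(Nc1cccc(-n2cc(-c3ccncc3)c(-c3cc(O)cc(Cl)c3)n2)c1)Nc1ccc(Cl)c(C(F)(F)F)c1`, in a functional assay on SN12C cells (Homo sapiens) for inhibition, read by sulforhodamine B assay, with a stated time of 48 h, tested at 1 uM; a higher number here means a weaker effect of the compound at the concentration tested, a lower number a stronger effect: 97%
compound 2, `O=C(Nc1cccc(-n2cc(-c3ccncc3)c(-c3cc(O)cc(Cl)c3)n2)c1)Nc1ccc(Cl)c(Cl)c1`, in this assay: 58%
compound 3, `COc1cc(Cl)cc(-c2nn(-c3cccc(NC(=O)Nc4ccc(Cl)c(C(F)(F)F)c4)c3)cc2-c2ccncc2)c1`, in this assay: 63%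

Compound 3 stands second highest of the three numbers. Its nearest neighbour is compound 2, whose number is lower by an amount within the scatter, so the two cannot be ranked against each other. Compound 1 lies furthest away: the step of a number 34 percentage points lower from compound 1 to compound 3 (beyond the scatter) is beyond the scatter.

Compound 4, `COc1cc(Cl)cc(-c2nn(-c3cccc(NC(=O)Nc4ccc(Cl)c(Cl)c4)c3)cc2-c2ccncc2)c1`, differs from compound 3 in one place: chloro in place of trifluoromethyl on an aromatic carbon. The measured step that bears directly on this change is a number 39 percentage points lower from compound 1 to compound 2 (beyond the scatter), the same replacement made on the pair carrying the free hydroxyl. Whether that step carries over unchanged to the methoxy pair, in which a number 34 percentage points lower from compound 1 to compound 3 (beyond the scatter) has already moved the number downward, cannot be told from three compounds; a downward step of smaller size than the first one is the more cautious expectation. Compound 4 is therefore expected to take a step of a number 25 percentage points lower from compound 3 to compound 4 (beyond the scatter). Compound 4 is estimated at 38%, with a range from 18% to 62%.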

Compound 4, a percentage reported as activity, at one concentration (the size of the read-out at that concentration, not a potency): 87%
Estimate against measurement, compound 4: 49 percentage points below; measured number above the stated range.
By their numbers in this assay, from the lowest: compounds 2 and 3 (each within the scatter of the next); then compounds 4 and 1 (each within the scatter of the next).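

On this position the replacement of 4-chloro-3-(trifluoromethyl)phenyl by 3,4-dichlorophenyl has no fixed direction in this assay: with the methoxy group in place, the change gives a number 24 percentage points higher from compound 3 to compound 4 (beyond the scatter), whereas with the free hydroxyl it moved the number the other way: the same change on two cores in this assay, a number 39 percentage points lower (beyond the scatter) from compound 1 to compound 2 and a number 24 percentage points higher (beyond the scatter) from compound 3 to compound 4, 63 percentage points apart, beyond the scatter of two such steps

The methyl on the oxygen reverses in the same way, giving a number 29 percentage points higher from compound 2 to compound 4 (beyond the scatter) when the 3,4-dichlorophenyl group is present, so its earlier downward step does not hold on both cores: the same change on two cores in this assay, a number 34 percentage points lower (beyond the scatter) from compound 1 to compound 3 and a number 29 percentage points higher (beyond the scatter) from compound 2 to compound 4, 63 percentage points apart, beyond the scatter of two such steps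

Across these four compounds the two changes therefore do not add: compounds 2 and 3, each carrying one of them, share the low numbers, while compounds 1 and 4, carrying neither or both, share the high numbers and cannot be ranked against each other.

The compounds shown leave open whether this reversal is particular to chloro and trifluoromethyl, or would also appear with a bromo, a methyl or a nitrile at the same place. They also leave open whether it would persist if the oxygen carried an ethyl group, and whether it would hold at other concentrations, since a single-concentration read-out gives no potency.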